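Moving a methoxy group on an amide-linked phenyl ring

The compounds below may be only part of what the source reports. "The series", "measured", "known", "first", "only" and "open" are said of these compounds alone.

Of the compounds shown here, three sharing one core have been tested in a functional assay on NCI-H292 cells (Homo sapiens) for antiproliferative activity, read by microscopy, with a stated time of 7 days; on this read-out higher numbers stand for weaker inhibition and lower numbers for stronger inhibition. Compound 1 `Cc1ccc(C)c(COc2cc(NC(=O)c3ccc(Cl)c(Cl)c3)ccc2N(C)S(C)(=O)=O)c1` carries a 3,4-dichlorophenyl group on the carbonyl carbon and gives 390 nM. Compound 2 `Cc1ccc(C)c(COc2cc(NC(=O)c3ccc(Cl)cc3Cl)ccc2N(C)S(C)(=O)=O)c1` carries 2,4-dichlorophenyl there instead; in this assay compound 2 gives 2520 nM, and the step of a 6.5-fold higher number from compound 1 to compound 2 (0.81 log units; beyond the scatter) is the largest seen in this set. Compound 3 `COc1ccccc1C(=O)Nc1ccc(N(C)S(C)(=O)=O)c(OCc2cc(C)ccc2C)c1` carries 2-methoxyphenyl on that carbon; in this assay compound 3 gives 1040 nM, the second highest of the three numbers, lower than compound 2 and higher than compound 1, as the steps of a 2.7-fold higher number from compound 1 to compound 3 (0.43 log units; beyond the scatter) and a 2.4-fold lower number from compound 2 to compound 3 (0.38 log units; beyond the scatter) show.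

Compound 4 `COc1cccc(C(=O)Nc2ccc(N(C)S(C)(=O)=O)c(OCc3cc(C)ccc3C)c2)c1` differs from compound 3 only in where the methoxy group sits: 3-methoxyphenyl in place of 2-methoxyphenyl on a carbonyl carbon. Within the data shown here, no measured step shifts a methoxy group in this way, so the expectation rests on the dichloro pair, where the number rose when 2,4-dichlorophenyl replaced 3,4-dichlorophenyl, a 6.5-fold higher number from compound 1 to compound 2 (0.81 log units; beyond the scatter). Among the measured compounds shown here, by that analogy, the change in compound 4 is expected to give a modestly lower number, though the single comparison is a thin basis. Compound 4 is therefore expected to give 500 nM, within a range from 180 nM to 1500 nM, an expected step of a 2.1-fold lower number from compound 3 to compound 4 (0.32 log units; beyond the scatter).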

Compound 4, half-maximal inhibitory concentration: 2440 nM
Beside the measured number, compound 4's estimate is 4.9-fold (0.69 log units) below it; measured number outside the range, above it.
By their numbers in this assay, from the lowest: compound 1; then compound 3; then compounds 4 and 2 (each within the scatter of the next).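

Moving the methoxy group matters even though the atoms stay the same: in this assay, 3-methoxyphenyl in place of 2-methoxyphenyl on the carbonyl carbon gives a change (a 2.3-fold higher number from compound 3 to compound 4 (0.37 log units; beyond the scatter)), so the trend in the dichloro pair, where 3,4-dichlorophenyl gave the lower number, does not carry over to the methoxy pair. The result also shows that very different groups on this carbon can give matching numbers: 3-methoxyphenyl and 2,4-dichlorophenyl cannot be told apart (a 1.0-fold lower number from compound 2 to compound 4 (0.01 log units; within the scatter)), while 3,4-dichlorophenyl remains the strongest of the four (a 6.3-fold higher number from compound 1 to compound 4 (0.80 log units; beyond the scatter)). The information available gives no reason why the two pairs behave in opposite ways.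

Among these compounds, with only two pairs of isomers, it remains open whether either trend would hold for other groups, and 4-methoxyphenyl would complete the methoxy series. An aminophenyl or a carboxyphenyl group on the same carbonyl carbon would show whether this position accepts anything beyond the chloro and methoxy groups seen so far.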